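The source may hold more compounds than are shown below. What is called first, only, known or untested is meant among the compounds shown, and "the series" means these compounds.

Compound 2 `c1ccc(-c2nc(SCC3OCCO3)[nH]c2-c2ccccc2)cc1` is the weaker of the two measured inhibitors in an assay on microsomes from liver for inhibition of sterol O-acyltransferase 1 (Rattus norvegicus); a lower number here means a stronger inhibitor, a higher number a weaker inhibitor: compound 2 gives 530 nM, while compound 1 `C[C@]1(O)CC(=O)OC(CSc2nc(-c3ccccc3)c(-c3ccccc3)[nH]2)C1` gives 140 nM, and the change from compound 1 to compound 2 cost a 3.8-fold higher number from compound 1 to compound 2 (0.58 log units; beyond the scatter). Compound 3 `COC(CSc1nc(-c2ccccc2)c(-c2ccccc2)[nH]1)OC` differs from compound 2 by dimethoxymethyl in place of 1,3-dioxolan-2-yl on a saturated chain carbon bound to a sulfur. Among the compounds with values here, the one measured step touches the same position but a different group, so it only indirectly bears on this change; it suggests that alterations of the group on the chain carbon bound to sulfur can shift this assay by a modest amount. Compound 3 is therefore expected to give about 650 nM, between 250 nM and 1700 nM, a step of a 1.2-fold higher number from compound 2 to compound 3 (0.09 log units; within the scatter) that is expected to stay close to the scatter.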

Compound 3, half-maximal inhibitory concentration: 580 nM
Compound 3: the middle estimate sits 1.1-fold (0.05 log units) above what was measured; measured number inside the range.
By their numbers in this assay, from the lowest: compound 1; then compounds 2 and 3 (each within the scatter of the next).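

Putting dimethoxymethyl in place of 1,3-dioxolan-2-yl removes the ring but leaves this assay within the scatter (a 1.1-fold higher number from compound 2 to compound 3 (0.04 log units; within the scatter)), so at this position the ring of compound 2 makes no readable difference. The ring-free group also falls short of the larger group in compound 1 (a 4.1-fold higher number from compound 1 to compound 3 (0.62 log units; beyond the scatter)), by a step beyond the scatter and of the same modest size as that for compound 2. Nothing available explains this result. Still open, from the compounds shown here alone, is how an amine or a carboxylic acid on the saturated chain carbon bound to a sulfur would read in this assay.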